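Compound 3: 2-hydroxyphenyl in place of 3-bromophenyl

The compounds below may be only part of what the source reports. "The series", "measured", "known", "first", "only" and "open" are said of these compounds alone.

In a functional assay on the whole organism for inhibition, with Rattus norvegicus as the target (on this read-out lower numbers stand for an effect already at smaller amounts and higher numbers for an effect only at larger amounts of compound), compound 2 `CC1CC/C(=N\Nc2cccc(Br)c2)c2ncc(C(=O)O)c(=O)n21` gives 0.4 umol/kg. Within the data shown here, its only measured neighbour, compound 1 `CC1CC/C(=N\Nc2cccc(Cl)c2)c2ncc(C(=O)O)c(=O)n21`, gives 0.6 umol/kg in this assay; the step of a 1.5-fold lower number from compound 1 to compound 2 (0.18 log units; within the scatter) leaves the two standing together, so compound 2 has no separate position beyond that of compound 1. Compound 3 `CC1CC/C(=N\Nc2ccccc2O)c2ncc(C(=O)O)c(=O)n21` differs from compound 2 in one place: 2-hydroxyphenyl in place of 3-bromophenyl on an amine nitrogen. Among the measured compounds shown here, no measured step bears directly on this change. For the measured compounds named here, the single step known, a 1.5-fold lower number from compound 1 to compound 2 (0.18 log units; within the scatter), swaps one halogen for another and carries no information on 2-hydroxyphenyl entering on the amine nitrogen. The exchange is thus judged without precedent here, and a step beyond the scatter in either direction cannot be ruled out. On balance a somewhat higher number is expected for compound 3, an expected step of a 2.5-fold higher number from compound 2 to compound 3 (0.40 log units; beyond the scatter). Compound 3 is therefore estimated at 1 umol/kg in this assay, within a range from 0.3 umol/kg to 4 umol/kg.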

Compound 3, dose for 50% inhibition: 0.26 umol/kg
For compound 3 the middle estimate is 3.8-fold (0.59 log units) above the measured one, and the stated range ends above it.
By their numbers in this assay, from the lowest: compounds 3, 2 and 1 (each within the scatter of the next, the first and the last beyond it).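

In this assay, 2-hydroxyphenyl on the amine nitrogen stands with 3-bromophenyl, at a 1.5-fold lower number from compound 2 to compound 3 (0.19 log units; within the scatter), so a halogen on this ring is not required for a number in this low range. Against 3-chlorophenyl the same exchange gives a 2.3-fold lower number from compound 1 to compound 3 (0.36 log units; beyond the scatter), a modest step and the only one among these compounds that clears the scatter. Nothing available explains either step.

Since this exchange alters both the group on the ring and where it sits, the compounds shown do not separate those two changes, and 3-hydroxyphenyl or 2-bromophenyl would be needed to do so. As far as these compounds go, it also remains open how plain phenyl, 2-methoxyphenyl or 2-aminophenyl would read at this place, and what happens when the carboxylic acid of the shared core is replaced by an amide.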